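The source may report more compounds than this note shows. Statements on the series, on what has been measured and on what is new or still open speak of the compounds shown alone.

Compounds measured so far, all in an assay for activation of histidine kinase 3 (Arabidopsis thaliana), read by a beta-galactosidase reporter; a higher number here means that more compound is needed for the effect, a lower number that less compound is needed:

Compound 1 `COc1cccc(Nc2nc(Cl)nc3[nH]cnc23)c1` gives 21000 nM.
Compound 2 `Clc1cccc(Nc2nc(Cl)nc3[nH]cnc23)c1` gives 10700 nM.
Compound 3 `COc1ccc(Nc2nc(Cl)nc3[nH]cnc23)cc1` gives 33100 nM.

Among these three, compound 2 has the lowest number. Its nearest neighbour is compound 1, and the difference between them is within the scatter, so the two cannot be told apart with confidence; compound 3 sits further away, beyond the scatter. Among the compounds with values here, the one measured step that touches compound 2, a chloro in place of a methoxy on the aromatic carbon, gave a 2.0-fold lower number from compound 1 to compound 2 (0.29 log units; within the scatter).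

Compound 4 `Fc1cccc(Nc2nc(Cl)nc3[nH]cnc23)c1` differs from compound 2 by fluoro in place of chloro on an aromatic carbon. Within the data shown here, no measured step swaps one of these two groups for the other, so there is no direct guide to the size of the change. Among the measured compounds shown here, the only nearby step, that from compound 1 to compound 2, stayed within the scatter, and the expectation is a step of similar smallness: compound 4 is expected to show a 1.3-fold higher number from compound 2 to compound 4 (0.12 log units; within the scatter) in this assay, most likely with no change beyond the scatter. The estimate for compound 4 is 14000 nM, with a range from 6000 nM to 35000 nM.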

Compound 4, half-maximal effective concentration: 6000 nM
The estimate for compound 4 lay 2.3-fold (0.37 log units) above the measured number, within the range that was stated.
By their numbers in this assay, from the lowest: compounds 4, 2, 1 and 3 (each within the scatter of the next, the first and the last beyond it).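

In this assay the swap of chloro for fluoro at this position gives a step (a 1.8-fold lower number from compound 2 to compound 4 (0.25 log units; within the scatter)) that stays within the scatter, so these two halogens cannot be told apart here. Within the data shown here, the swap of methoxy for fluoro at the same position gives a step (a 3.5-fold lower number from compound 1 to compound 4 (0.54 log units; beyond the scatter)) that is modest but beyond the scatter, which is the first clear sign that the group at this position can affect the number needed in this assay. Nothing available explains this difference between the groups.

On these data alone, it remains open whether plain hydrogen, an amine, a nitrile, a trifluoromethyl or a longer chain at this position would lower or raise the number further. As far as these compounds go, whether fluoro would behave the same way elsewhere on the ring also remains open.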